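The source may report more compounds than this note shows. Statements on the series, on what has been measured and on what is new or still open speak of the compounds shown alone.

In a functional assay on SMMC-7721 cells (Homo sapiens) for cytotoxicity, read by MTT assay, with a stated time of 72 h (a lower number here means a stronger inhibitor, a higher number a weaker inhibitor), three compounds sharing one core have been measured. Compound 1 (`O=C1C(=Cc2ccc(O)cc2)C(=O)N(c2ccc(Cl)cc2)N1c1ccc(Cl)cc1`) gives 20600 nM and compound 2 (`O=C1C(=Cc2ccc(F)cc2)C(=O)N(c2ccc(Cl)cc2)N1c1ccc(Cl)cc1`) gives 23300 nM. Compound 3 (`COc1cccc(C=C2C(=O)N(c3ccc(Cl)cc3)N(c3ccc(Cl)cc3)C2=O)c1O`) gives 64900 nM, the highest number of the three, which makes it the weakest inhibitor so far. The next compound, compound 4 (`COc1cccc(C=C2C(=O)N(c3ccc(Cl)cc3)N(c3ccc(Cl)cc3)C2=O)c1OC`), has not yet been measured. It differs from compound 3 by one small change (methyl in place of hydrogen on an oxygen on an aromatic ring): methyl in place of hydrogen on an oxygen on an aromatic ring, turning 2-hydroxy-3-methoxyphenyl into 2,3-dimethoxyphenyl.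

Within the data shown here, no measured step makes exactly this change, so the evidence is indirect. The closest is a 1.1-fold higher number from compound 1 to compound 2 (0.05 log units; within the scatter), where a hydroxy was replaced by fluoro at another place and the number barely moved. The two steps that introduced the 2-hydroxy-3-methoxyphenyl group were modest: a 3.2-fold higher number from compound 1 to compound 3 (0.50 log units; beyond the scatter) and a 2.8-fold higher number from compound 2 to compound 3 (0.44 log units; beyond the scatter). Nothing here points to a large effect from capping the hydroxy, and the direction is poorly defined. The expected step is a 1.3-fold lower number from compound 3 to compound 4 (0.11 log units; within the scatter), which would be no change beyond the scatter. Compound 4 is estimated at about 50000 nM, with an expected range from 22000 nM to 110000 nM.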

Compound 4, half-maximal inhibitory concentration: 14100 nM
Compound 4: middle estimate off by 3.5-fold (0.55 log units), on the high side; measured number outside the range, below it.
By their numbers in this assay, from the lowest: compounds 4, 1 and 2 (each within the scatter of the next); then compound 3.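

In this assay, turning the hydroxy of 2-hydroxy-3-methoxyphenyl into a methoxy is not a silent change: a 4.6-fold lower number from compound 3 to compound 4 (0.66 log units; beyond the scatter). The single added methyl removes the gap that made compound 3 the weakest of the set, and compound 4 cannot be separated from the other two, with a 1.7-fold lower number from compound 2 to compound 4 (0.22 log units; within the scatter) and a 1.5-fold lower number from compound 1 to compound 4 (0.16 log units; within the scatter). A free hydroxy does not always go with a weaker number, though, as compound 1 carries one on its 4-hydroxyphenyl and still falls within the scatter of compound 4. Nothing measured here explains why capping this oxygen shifts the number.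

Going by these compounds, what an ethyl on this oxygen, or an amine in place of the hydroxy, would do remains open. Also open, on these data alone, is whether the same capping would shift the number for the 4-hydroxyphenyl of compound 1, where the step from hydroxy to methoxy would fall at a different place on the ring.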